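Aminoethyl Thioether on a Pyrazolopyrimidine Aminopyridyl Series

The source may report more compounds than this note shows. Statements on the series, on what has been measured and on what is new or still open speak of the compounds shown alone.

Compound 1 `CC(C)c1n[nH]c2c(NCc3ccc(-c4ccccn4)cc3)nc(SC[C@H](O)CN)nc12`: 63 nM
Compound 2 `CC(C)c1n[nH]c2c(NCc3ccc(-c4ccccn4)cc3)nc(SC(CO)C(C)C)nc12`: 980 nM
Compound 3 `CC(C)c1n[nH]c2c(NCc3ccc(-c4ccccn4)cc3)nc(SC3CCCC3O)nc12`: 567 nM

In a functional assay on HT cells (Homo sapiens) for antiproliferative activity, read by fluorescence, with a stated time of 72 h (a lower number here means a stronger inhibitor of growth, a higher number a weaker inhibitor of growth), compound 3 gives the second highest of the three numbers; its nearest neighbour is compound 2 a 1.7-fold lower number from compound 2 to compound 3 (0.24 log units; within the scatter), and compound 1 lies furthest from it a 9.0-fold higher number from compound 1 to compound 3 (0.95 log units; beyond the scatter). Compound 4 `CC(C)c1n[nH]c2c(NCc3ccc(-c4ccccn4)cc3)nc(SCCN)nc12` differs from compound 3 by 2-aminoethyl in place of 2-hydroxycyclopentyl on a sulfur. Within the data shown here, the step that bears on this is the one from compound 1, which also carries an amine on its sulfur chain, to compound 3; that step was modest and beyond the scatter. The reverse direction is therefore expected here, a lower number in this assay, though the chain of compound 4 is shorter than that of compound 1 and lacks its hydroxyl. The estimated value for compound 4 is 130 nM (range 45 nM to 400 nM), a step of a 4.4-fold lower number from compound 3 to compound 4 (0.64 log units; beyond the scatter).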

Compound 4, concentration for 50% growth inhibition: 22 nM
Beside the measured number, compound 4's estimate is 5.9-fold (0.77 log units) above it, outside the stated range (below it).
By their numbers in this assay, from the lowest: compound 4; then compound 1; then compounds 3 and 2 (each within the scatter of the next).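

In this assay, 2-aminoethyl on the sulfur gives large steps from both amine-free chains (a 26-fold lower number from compound 3 to compound 4 (1.41 log units; beyond the scatter)) (a 45-fold lower number from compound 2 to compound 4 (1.65 log units; beyond the scatter)), so this small chain with no ring surpasses both of them. The amine-bearing chain of compound 1 does not need its hydroxyl or its greater length to give a low number, as the shorter chain goes further (a 2.9-fold lower number from compound 1 to compound 4 (0.46 log units; beyond the scatter)). Nothing shown here explains these steps. The compounds shown leave open whether the amine itself is decisive, as a 2-hydroxyethyl chain would test, and whether a 3-aminopropyl chain would hold the gain.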